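A few compounds are considered here, and "the series" means these few. Any claim that something is new, unique, unknown or untested is made for them only; others in the source may bear on it.

Measured compounds in a functional assay on CCRF-CEM cells (Homo sapiens) for inhibition, read by sulforhodamine B assay, with a stated time of 48 h; on this read-out lower numbers stand for stronger inhibition of growth and higher numbers for weaker inhibition of growth:
- compound 1 `COc1cc(-c2nn(-c3cccc(NC(=O)c4ccc(Cl)c(C(F)(F)F)c4)c3)cc2-c2ccncc2)ccc1Cl` gives 1770 nM
- compound 2 `COc1cc(-c2nn(-c3cccc(NC(=O)c4cccc(C(F)(F)F)c4)c3)cc2-c2ccncc2)ccc1Cl` gives 1450 nM
- compound 3 `O=C(Nc1cccc(-n2cc(-c3ccncc3)c(-c3ccc(Cl)c(O)c3)n2)c1)Nc1cc(C(F)(F)F)cc(C(F)(F)F)c1` gives 789 nM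

Compound 3 has the lowest number of the three. Its gap to compound 2 is within the scatter, so the two cannot be ranked against each other; its gap to compound 1 is beyond the scatter. Compound 4 `O=C(Nc1cccc(-n2cc(-c3ccncc3)c(-c3ccc(Cl)c(O)c3)n2)c1)Nc1cccc(C(F)(F)F)c1` differs from compound 3 in one place: hydrogen in place of trifluoromethyl on an aromatic carbon.

Within the data shown here, no measured pair removes a trifluoromethyl group. Among the measured compounds shown here, the nearest guide is the single step between measured compounds, in which a chloro group on an aromatic carbon is replaced by hydrogen: a 1.2-fold lower number from compound 1 to compound 2 (0.09 log units; within the scatter). That removal of a small aromatic substituent left the number essentially unchanged. By analogy, only a modest shift is expected for compound 4, perhaps towards a somewhat higher number, but not clearly beyond the scatter.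

For compound 4 the expected step in this assay is a 1.4-fold higher number from compound 3 to compound 4 (0.14 log units; within the scatter). Compound 4 is therefore estimated at 1100 nM, with a range from 500 nM to 2500 nM.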

Compound 4, concentration for 50% growth inhibition: 1400 nM
For compound 4 the middle estimate is 1.3-fold (0.10 log units) below the measured one, and the stated range covers the measured number.
By their numbers in this assay, from the lowest: compounds 3, 4, 2 and 1 (each within the scatter of the next, the first and the last beyond it).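

In this assay, removing one of the two trifluoromethyl groups of compound 3 gives a 1.8-fold higher number from compound 3 to compound 4 (0.25 log units; within the scatter) and so leaves growth inhibition indistinguishable from that of the parent. Among these compounds, this is the first view of this group at this place, and it shows that a substituent of 4 heavy atoms can give way to hydrogen without a change that stands clear of the usual scatter, provided the other trifluoromethyl group stays on the ring. Nothing measured here explains this result.

The compounds shown leave open whether the remaining trifluoromethyl group can also be replaced by hydrogen without a clear change. They also leave open how the number would respond if an amine, a carboxylic acid or a longer chain stood at this place instead.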